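The compounds below may be only part of what the source reports. "The series", "measured", "known", "first", "only" and "open" are said of these compounds alone.

Three compounds of this series have been measured in a functional assay on T47D cells (Homo sapiens) for cytotoxicity, read by CCK-8 assay, with a stated time of 4 days; a lower number here means a stronger inhibitor, a higher number a weaker inhibitor:

compound 1 `Oc1ccccc1-c1cc(-c2ccccc2O)nc(-c2ccccc2O)c1`: 2510 nM
compound 2 `Oc1cccc(-c2cc(-c3ccccc3O)cc(-c3cccc(O)c3)n2)c1`: 4570 nM
compound 3 `Oc1ccc(-c2cc(-c3ccccc3O)cc(-c3ccccc3O)n2)cc1`: 960 nM

Compound 3 gives the lowest number of the three. The step of a 2.6-fold lower number from compound 1 to compound 3 (0.42 log units; beyond the scatter) separates it from compound 1, and compound 2 lies further off, with a higher number than either.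

Compound 4 `Oc1cccc(-c2cc(-c3ccccc3O)cc(-c3ccccc3O)n2)c1` has not been measured. It differs from compound 3 by 3-hydroxyphenyl in place of 4-hydroxyphenyl on an aromatic carbon. Among the compounds with values here, no measured pair isolates this exact exchange. Within the data shown here, the only step on record, a 2.6-fold lower number from compound 1 to compound 3 (0.42 log units; beyond the scatter), concerns a different exchange at the same aromatic carbon and is modest in size. Beyond that, compounds 1 and 2, neither of which carries a 4-hydroxyphenyl, both give higher numbers than compound 3, and compound 2, which carries two 3-hydroxyphenyl groups, gives the highest number of the three. Taken together these values suggest that giving up the 4-hydroxyphenyl will cost potency, and the step from compound 3 to compound 4 is expected to be a 3.1-fold higher number from compound 3 to compound 4 (0.49 log units; beyond the scatter).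

In this assay compound 4 is estimated at 3000 nM, with a range from 1200 nM to 7500 nM.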

Compound 4, half-maximal inhibitory concentration: 5760 nM
The estimate for compound 4 lay 1.9-fold (0.28 log units) below the measured number; low and high end bracket the measured number.
By their numbers in this assay, from the lowest: compound 3; then compounds 1, 2 and 4 (each within the scatter of the next, the first and the last beyond it).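

At the carbon next to the ring nitrogen, the position of the hydroxyl on the phenyl ring now has a direct reading in this assay: moving it gives a 6.0-fold higher number from compound 3 to compound 4 (0.78 log units; beyond the scatter) and, set against the 2-hydroxyphenyl, a 2.3-fold higher number from compound 1 to compound 4 (0.36 log units; beyond the scatter), so with a 2.6-fold lower number from compound 1 to compound 3 (0.42 log units; beyond the scatter) all three isomers at this carbon are separated beyond the scatter, and the 4-hydroxyphenyl of compound 3 gives the lowest number. Within the data shown here, the exchange of 2-hydroxyphenyl for 3-hydroxyphenyl linking the other pair behaves differently, with a 1.3-fold higher number from compound 2 to compound 4 (0.10 log units; within the scatter) lying within the scatter, so that exchange shows no effect in this pair, while the same two groups differ beyond the scatter between the pair compound 1 and compound 4. Nothing available explains these differences.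

As far as these compounds go, it remains open whether the low number of compound 3 depends on the hydroxyl itself, which a 4-methoxyphenyl or a 4-aminophenyl at this carbon would test. Also open, from the compounds shown here alone, is whether a 4-hydroxyphenyl in place of either 2-hydroxyphenyl group of compound 3 would lower the number further.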